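The compounds below may be only part of what the source reports. "The series", "measured", "known", "first", "only" and "open" are said of these compounds alone.

Measured compounds in a functional assay on IGROV-1 cells (Homo sapiens) for cytotoxicity, read by sulforhodamine B assay, with a stated time of 48 h, tested at 0.01 uM; a lower number here means a stronger effect, a higher number a weaker effect of the compound at the concentration tested:
compound 1, `COc1cc(C)cc(-c2c(-c3ccnc(-c4ccc(C(C)=O)cc4)c3)cnn2CC#N)c1`, gives 94%
compound 2, `Cc1cc(O)cc(-c2nn(CC#N)cc2-c2ccnc(-c3ccc(Oc4ccccc4)cc3)c2)c1`, gives 83%

Compound 1 stands highest of the two numbers in this assay; its nearest neighbour is compound 2, whose value lies lower by a gap beyond the usual scatter. For the measured compounds named here, no step between two measured compounds that differ in one place has been recorded, so the pair says only what its two values show, and no pattern is claimed from it.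

Compound 3, `COc1cc(C)cc(-c2c(-c3ccnc(-c4ccc(N(C)C)cc4)c3)cnn2CC#N)c1`, is not yet measured in this assay. It differs from compound 1 in one place: dimethylamino in place of acetyl on an aromatic carbon. Nothing in the measured pair speaks to this exchange.

Going by the values given here, with no recorded step of this kind, the expectation rests on compound 1 alone. Given that compound 1 gives 94% in this assay, a step from compound 1 to compound 3 of a number 4 percentage points lower from compound 1 to compound 3 (within the scatter) is expected, that is, no step beyond the scatter in either direction. The value estimated for compound 3 in this assay is 90%, with a range from 74% to 104%.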

Compound 3, a percentage reported as activity, at one concentration (the size of the read-out at that concentration, not a potency): -3%
Beside the measured number, compound 3's estimate is 93 percentage points above it; the whole stated range lies above it.
By their numbers in this assay, from the lowest: compound 3; then compound 2; then compound 1.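

Notes on the series: the position on the six-membered aromatic ring of carbon only, para to a large group, strongly affects the read-out in this assay, where dimethylamino in place of acetyl gives a number 97 percentage points lower from compound 1 to compound 3 (beyond the scatter). The two groups carry the same counts of heavy atoms, hydrogen-bond donors and hydrogen-bond acceptors, so these counts do not separate 4-acetylphenyl from 4-(dimethylamino)phenyl, and a single exchange of this size shows that the outcome at this concentration depends on which of the two groups stands at this place. No measurement shown here accounts for the step.

As far as these compounds go, it remains open whether the step follows the nitrogen of the amine, as a primary amine, a diethylamino group or a pyrrolidine at the same place would test, or whether a methyl ether there would behave in the same way. Also open, from the compounds shown here alone, is whether the step persists with the methoxy group of the core of compound 3 replaced by a hydroxyl, and how it appears at other concentrations, since a single-concentration read-out is not a potency.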